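A few compounds are considered here, and "the series" means these few. Any claim that something is new, unique, unknown or untested is made for them only; others in the source may bear on it.

Measured compounds:
compound 1 `CC(C)OC(=O)C(=O)Nc1cccccc1=O`: 72%
compound 2 `CCOC(=O)COC(=O)C(=O)Nc1cccccc1=O`: 64%

In a functional assay on the whole organism (strain Sprague-Dawley CD) for inhibition, with Rattus norvegicus as the target, read by paw edema, at a dose of 100 mg/kg by the oral route (on this read-out lower numbers stand for a weaker effect and higher numbers for a stronger effect at the one dose given), compound 2 gives 64%; compound 1 gives 72%, within the scatter of it, so the two are not separable on these numbers. Compound 3 `O=C(Nc1cccccc1=O)C(=O)Oc1ccccc1` differs from compound 2 by phenyl in place of (ethoxycarbonyl)methyl on an oxygen next to a carbonyl group. Within the data shown here, the only measured step at this place, a number 8 percentage points lower from compound 1 to compound 2 (within the scatter), also swapped the group on that oxygen and stayed within the scatter. On that basis no change beyond the scatter is expected for compound 3. The expected step is a number 1 percentage points higher from compound 2 to compound 3 (within the scatter), within the scatter. For compound 3 the expected value is 65%, with a range of 50% to 80%.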

Compound 3, a percentage reported as inhibition, in the whole organism at one dose (the size of the read-out at that dose, not a potency): 71%
Beside the measured number, compound 3's estimate is 6 percentage points below it, and the stated range covers the measured number.
By their numbers in this assay, from the lowest: compounds 2, 3 and 1 (each within the scatter of the next).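

In this assay, phenyl on an oxygen next to a carbonyl group, the first ring at this place, gives no step beyond the scatter against either earlier group (a number 7 percentage points higher from compound 2 to compound 3 (within the scatter); a number 1 percentage points lower from compound 1 to compound 3 (within the scatter)). Isopropyl, (ethoxycarbonyl)methyl and phenyl therefore cannot be separated at this place on these numbers. No further measurement bears on this result.

Open, going by these compounds, is whether a group carrying an amine, or a longer chain, on this oxygen would stay within the scatter too. With one dose, any potency difference among these three compounds also remains open.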